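Moving the ring nitrogen: compound 2 to compound 4

The source may hold more compounds than are shown below. What is called first, only, known or untested is meant among the compounds shown, and "the series" means these compounds.

Of the compounds shown here, three sharing one core have been measured in an assay on isolated protein for inhibition of ubiquitin carboxyl-terminal hydrolase 7 (Homo sapiens), read by fluorescence, with stated times of 30 min and 1 h; a higher number here means a weaker inhibitor, a lower number a stronger inhibitor. Compound 1 `Cc1cc(Cl)cc(-c2ccnc3cc(CN4C(=O)C5C(C4=O)C5(C)C)sc23)c1OC1CCCNC1` gives 2.4 nM; compound 2 `Cc1cc(Cl)cc(-c2ccnc3cc(CN4C(=O)CCC4=O)sc23)c1OC1CCNCC1` gives 8 nM; compound 3 `Cc1cc(Cl)cc(-c2ccnc3cc(CN4C(=O)C5CC5C4=O)sc23)c1C[C@@H]1CNCCO1` gives 0.16 nM. Compound 2 therefore shows the highest number of the three, standing beyond the scatter above compound 1 and far beyond it above compound 3. No pair of these compounds differs in only one place, so no single step can be read directly from the measured set.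

Compound 4 `Cc1cc(Cl)cc(-c2ccnc3cc(CN4C(=O)CCC4=O)sc23)c1O[C@H]1CCCNC1` has not yet been measured. It keeps every atom of compound 2 but joins them differently: piperidin-3-yl in place of piperidin-4-yl on an oxygen on an aromatic ring. Compound 1, which also carries a piperidin-3-yl on that oxygen though it differs from compound 4 elsewhere as well, gives a lower number than compound 2 in this assay, so the change is expected to move compound 4 towards a lower number rather than a higher one. Compound 4 is expected to give 4 nM, within a range from 1 nM to 15 nM. This estimate means a step from compound 2 to compound 4 of a 2.0-fold lower number from compound 2 to compound 4 (0.30 log units; within the scatter), expected to be modest but beyond the scatter.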

Compound 4, half-maximal inhibitory concentration: 4.6 nM
For compound 4 the middle estimate is 1.2-fold (0.06 log units) below the measured one; the measured number falls inside the stated range.
By their numbers in this assay, from the lowest: compound 3; then compounds 1, 4 and 2 (each within the scatter of the next, the first and the last beyond it).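

For the compounds shown here, the change of piperidin-4-yl to piperidin-3-yl on an oxygen on an aromatic ring is the first single change that can be read from this series, and in this assay it gives a 1.7-fold lower number from compound 2 to compound 4 (0.24 log units; within the scatter). Moving the ring nitrogen in this way, while adding a defined stereocentre, therefore leaves the inhibition within the scatter, and no order can be drawn between the two compounds. This holds only for the setting of compound 2, with its unsubstituted five-membered imide, and no measurement at hand bears on the reason for the result.

The compounds shown leave open whether the opposite configuration at the stereocentre of the piperidin-3-yl group would give a number close to that of compound 4, and whether this same change would read the same way with the other imide groups of the series. They also leave open how far this oxygen-linked position tolerates other amines, such as pyrrolidin-3-yl or azetidin-3-yl, or a methyl group on the ring nitrogen.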